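Methylated pyrazole on a pyrrolopyrimidine nitrile series

A few compounds are considered here, and "the series" means these few. Any claim that something is new, unique, unknown or untested is made for them only; others in the source may bear on it.

Compound 1 `C[C@@H]1CCCN1c1[nH]c2ncnc(N)c2c1C#N` and compound 2 `C[C@@H]1CCCN1c1c(C#N)c2c(N)nc(Nc3cn[nH]c3)nc2n1C` were both measured in an assay on isolated protein for binding affinity to Leucine-rich repeat serine/threonine-protein kinase 2 (Homo sapiens), read by TR-FRET and LanthaScreen, with a stated time of 2 h; a higher number here means a weaker inhibitor, a lower number a stronger inhibitor. Compound 1 gives 4 nM, while compound 2 gives 0.2 nM. Compound 2 therefore stands at the lowest of the two numbers, and its separation from compound 1 lies beyond the scatter of the measurement, so compound 2 counts as the stronger inhibitor of the pair.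

Compound 3 `Cc1c(Nc2nc(N)c3c(C#N)c(N4CCC[C@H]4C)n(C)c3n2)cnn1C` has not yet been measured. It differs from compound 2 in one place only: 1,5-dimethyl-1H-pyrazol-4-yl in place of 1H-pyrazol-4-yl on a nitrogen on an aromatic ring. Within the data shown here, no comparable step between measured compounds exists here, so the expectation rests on this change alone. The estimate for compound 3 in this assay is 0.6 nM, with a range from 0.15 nM to 3 nM. The expected step of a 3.0-fold higher number from compound 2 to compound 3 (0.48 log units; beyond the scatter) is a modest weakening, one that may not clearly exceed the scatter.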

Compound 3, inhibition constant: 2 nM
Compound 3: the middle estimate sits 3.3-fold (0.52 log units) below what was measured, and the stated range covers the measured number.
By their numbers in this assay, from the lowest: compound 2; then compounds 3 and 1 (each within the scatter of the next).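

Among these compounds, the change from 1H-pyrazol-4-yl to 1,5-dimethyl-1H-pyrazol-4-yl on a nitrogen on an aromatic ring gives a 10-fold higher number from compound 2 to compound 3 (1.00 log units; beyond the scatter) in this assay and is the first step that can be read at this place. It shows that affinity at this position responds to the group placed there, and here the larger group, with 7 heavy atoms against 5 and 0 hydrogen-bond donors against 1, is the weaker inhibitor. No measured evidence explains this loss.

The two methyl groups enter together, so the compounds shown do not separate their contributions, and 1-methyl-1H-pyrazol-4-yl or 5-methyl-1H-pyrazol-4-yl would be needed to do so. From the compounds shown here alone, whether a larger substituent on this pyrazole, such as an ethyl or a 2-hydroxyethyl group, would weaken binding further also stays open.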